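Carbamate-to-amide replacement on the piperidine nitrogen in the series

The compounds below may be only part of what the source reports. "The series", "measured", "known", "first", "only" and "open" are said of these compounds alone.

Compound 1 `CCC1(OC(=O)N2CCC(Oc3ncnc(Oc4ccc(S(C)(=O)=O)nc4C)c3F)CC2)CC1` is the reference point here. Within the data shown here, in a functional assay on isolated protein for inhibition of Glucose-dependent insulinotropic receptor (Rattus norvegicus), read by HTRF and cAMP accumulation (a higher number here means a larger maximal response, a lower number a smaller maximal response), compound 1 gives 83%, the highest of the three numbers so far. Compound 2 `Cc1nc(S(C)(=O)=O)ccc1Oc1ncnc(OC2CCN(C(=O)OC3COC3)CC2)c1F` gives 66% and compound 3 `Cc1nc(S(C)(=O)=O)ccc1Oc1ncnc(OC2CCN(C(=S)OC3(C)CC3)CC2)c1F` gives 49%; both sit below compound 1 beyond the scatter, with a number 17 percentage points lower from compound 1 to compound 2 (beyond the scatter) and a number 34 percentage points lower from compound 1 to compound 3 (beyond the scatter), and a number 17 percentage points lower from compound 2 to compound 3 (beyond the scatter) between them.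

Compound 4 `Cc1nc(S(C)(=O)=O)ccc1Oc1ncnc(OC2CCN(C(=O)C(C)(C)F)CC2)c1F` changes compound 1 at the same region that every measured step has touched: a group of 4 heavy atoms (3 carbon, 1 fluorine; no ring) in place of a group of 6 heavy atoms (5 carbon, 1 oxygen; one three-membered non-aromatic ring of carbon only), on a carbonyl carbon. Every alteration so far to the group carried by the ring nitrogen has cost maximal response, modestly in the step from compound 1 to compound 2 and heavily in the step from compound 1 to compound 3. Among the measured compounds shown here, no step exactly matching the loss of the ring-bearing alkoxy group in favour of a fluorinated alkyl on the carbonyl carbon is available, so the direction is taken from the two measured steps and the size placed between them. Compound 4 is therefore expected to fall below compound 1 by a number 21 percentage points lower from compound 1 to compound 4 (beyond the scatter), beyond the scatter. The estimate for compound 4 in this assay is 62%, within 45% to 80%.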

Compound 4, largest response reached (reported as efficacy), in percent of the reference or control that the assay uses: 74%
Compound 4: middle estimate off by 12 percentage points, on the low side; measured number inside the range.
By their numbers in this assay, from the lowest: compound 3; then compounds 2, 4 and 1 (each within the scatter of the next, the first and the last beyond it).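

Working notes: in this assay, 1-fluoro-1-methylethyl on the carbonyl carbon is the first change at this position to stay within the scatter of compound 1 (a number 9 percentage points lower from compound 1 to compound 4 (within the scatter)), even though it has no ring and no hydrogen-bond acceptor. A ring-bearing group on oxygen is therefore not needed for a response at this level among these compounds; the amide also stays within the scatter of the oxetane carbamate (a number 8 percentage points higher from compound 2 to compound 4 (within the scatter)) and clearly exceeds the thiocarbamate (a number 25 percentage points higher from compound 3 to compound 4 (beyond the scatter)). Nothing measured here bears on why the response holds with this group.

Whether the fluorine matters would be read from an isopropyl group on the same carbonyl carbon. From the compounds shown here alone, how a urea carrying a dimethylamino group there would stand also remains open.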